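Trading a diol for a single hydroxyl on the side chain

The compounds below may be only part of what the source reports. "The series", "measured", "known", "first", "only" and "open" are said of these compounds alone.

Compound 1 `OCC(O)Cn1nc2c(Br)c(Br)c(Br)c(Br)c2n1` is the weaker of the two measured compounds in a functional assay on CCRF-CEM cells (Homo sapiens) for antiproliferative activity, read by MTT assay, with a stated time of 48 h, tested at 50 uM (on this read-out higher numbers stand for a weaker effect at the one concentration tested and lower numbers for a stronger effect), where compound 1 gives 27%. Compound 2 `OC(CCn1nc2c(Br)c(Br)c(Br)c(Br)c2n1)c1cccc(Br)c1` gives 0% in this assay, a difference beyond the scatter. Compound 3 `C[C@H](O)CCn1nc2c(Br)c(Br)c(Br)c(Br)c2n1` differs from compound 1 by one change: 2-hydroxypropyl in place of 1,2-dihydroxyethyl on a saturated chain carbon bound to an aromatic nitrogen. For the measured compounds named here, no measured pair shows this change, so its effect is unknown. The expected step from compound 1 to compound 3 is a small one towards a stronger effect, a number 7 percentage points lower from compound 1 to compound 3 (within the scatter), likely within the scatter. Compound 3 is therefore estimated at 20%, with a range from 5% to 40%.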

Compound 3, a percentage reported as activity, at one concentration (the size of the read-out at that concentration, not a potency): 42%
Estimate against measurement, compound 3: 22 percentage points below; the whole stated range lies below it.
By their numbers in this assay, from the lowest: compound 2; then compound 1; then compound 3.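

In this assay, putting 2-hydroxypropyl in place of 1,2-dihydroxyethyl gives a number 15 percentage points higher from compound 1 to compound 3 (beyond the scatter), so this position does respond to the side chain, and here the change weakens the effect. The swap removes a hydrogen-bond donor and acceptor and adds a defined stereocentre, and this single pair cannot separate those differences. Nothing available explains the shift. On these data alone, whether a longer chain, an amine or a carboxylic acid at this place would strengthen the effect remains open. So does the result for the opposite stereoisomer of compound 3.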